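Chain length and linkage change on the para arm

The source may report more compounds than this note shows. Statements on the series, on what has been measured and on what is new or still open speak of the compounds shown alone.

For the measured compounds named here, compound 1 `CN(C)C(=O)c1cc2cnc(Nc3ccc(C(=O)NCCCN=C=S)cc3)nc2n1C1CCCC1` is the weakest of the three measured members. In a functional assay on A549 cells (Homo sapiens) for inhibition, read by CCK-8 assay, with a stated time of 72 h, tested at 1 uM (on this read-out higher numbers stand for a stronger effect at the one concentration tested and lower numbers for a weaker effect), compound 1 gives 32.9%, while compound 2 `CN(C)C(=O)c1cc2cnc(Nc3ccc(C(=O)NCCCCCCCN=C=S)cc3)nc2n1C1CCCC1` gives 73.7% and compound 3 `CN(C)C(=O)c1cc2cnc(Nc3ccc(C(=O)NCCCN=C=S)cc3O)nc2n1C1CCCC1` gives 55.9%. The step of a number 40.8 percentage points higher from compound 1 to compound 2 (beyond the scatter) shows that the larger chain group in place of the smaller one adds strongly; the step of a number 23 percentage points higher from compound 1 to compound 3 (beyond the scatter) is smaller and concerns a hydroxy at another position. Compound 4 `CN(C)C(=O)c1cc2cnc(Nc3ccc(NC(=O)CCCCCCN=C=S)cc3)nc2n1C1CCCC1` carries, relative to compound 1, (a group of 12 heavy atoms (8 carbon, 2 nitrogen, 1 oxygen, 1 sulfur; no ring) in place of a group of 9 heavy atoms (5 carbon, 2 nitrogen, 1 oxygen, 1 sulfur; no ring), on an aromatic carbon). Going by the values given here, the growth of the chain resembles the step from compound 1 to compound 2, so a rise is expected; the remainder of the change has no measured counterpart, which widens the range. The expected step is a number 29.1 percentage points higher from compound 1 to compound 4 (beyond the scatter). Compound 4 is therefore estimated at about 62%, within 42% to 82%.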

Compound 4, a percentage reported as inhibition, at one concentration (the size of the read-out at that concentration, not a potency): 43.3%
Compound 4: middle estimate off by 18.7 percentage points, on the high side; the range from low to high includes it.
By their numbers in this assay, from the lowest: compound 1; then compound 4; then compound 3; then compound 2.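

Growing the arm does not by itself bring a large gain: the group of 12 heavy atoms in place of the group of 9 heavy atoms, on an aromatic carbon para to a large group, gives a modest rise (a number 10.4 percentage points higher from compound 1 to compound 4 (beyond the scatter)), whereas the chain step alone gave a large one (a number 40.8 percentage points higher from compound 1 to compound 2 (beyond the scatter)). Chain growth and the change of linkage are joined in this single step, so their shares cannot be separated. No measurement at hand bears on the reason for this result.

On these data alone, it remains open whether a longer chain on the linkage of compound 4, or an amine at the chain end, would change the number.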